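Methyl for methoxy on the aryl group of compound 2

This account rests on a few compounds, and the source may have more. Where it says the series, first, only, none or still open, it means among the compounds named here.

- compound 1 `Cc1ccc(NCc2cn(-c3ccccc3)nc2-c2ccc(C)cc2)cc1` gives 7380 nM
- compound 2 `COc1ccc(-c2nn(-c3ccccc3)cc2CNc2ccc(F)cc2)cc1` gives 6580 nM

In a functional assay on B16-F10 cells (Mus musculus) for antiproliferative activity, read by MTT assay, with a stated time of 48 h (on this read-out lower numbers stand for stronger inhibition and higher numbers for weaker inhibition), compound 2 gives 6580 nM, and compound 1 gives 7380 nM. These two values lie within the usual scatter of each other, so compound 2 cannot be ranked ahead of compound 1 on these numbers.

The next compound to be tested is compound 3 `Cc1ccc(-c2nn(-c3ccccc3)cc2CNc2ccc(F)cc2)cc1`. It takes compound 2 and replaces the methoxy with a methyl on an aromatic carbon, turning the 4-methoxyphenyl into a 4-methylphenyl (methyl in place of methoxy on an aromatic carbon). For the measured compounds named here, no measured pair isolates this change, so the data give no direct size for it. Going by the values given here, the only indirect evidence is that compound 1, which also carries a 4-methylphenyl group, gives 7380 nM, close to the value of compound 2. The expectation in this assay is therefore no clear direction and no shift beyond the scatter. The estimated step of a 1.0-fold higher number from compound 2 to compound 3 (0.01 log units; within the scatter) stays within that scatter. For compound 3 the expected value is 6800 nM, with an estimated range from 3500 nM to 13000 nM.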

Compound 3, half-maximal inhibitory concentration: 5670 nM
Beside the measured number, compound 3's estimate is 1.2-fold (0.08 log units) above it; the range from low to high includes it.
By their numbers in this assay, from the lowest: compounds 3, 2 and 1 (each within the scatter of the next).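

In this assay, for the compounds shown here, the step of a 1.2-fold lower number from compound 2 to compound 3 (0.06 log units; within the scatter) is the first direct reading of methyl in place of methoxy on this aromatic carbon, para to a large group, and it shows that taking out the oxygen, with the one hydrogen-bond acceptor counted for the methoxy, does not separate the pair beyond the scatter. Going by these compounds alone, compound 3 also gives a first reading of fluoro in place of methyl on an aromatic carbon, a 1.3-fold lower number from compound 1 to compound 3 (0.11 log units; within the scatter), so this second place likewise shows no separation on these numbers. No measurement other than the antiproliferative read-out bears on this result.

As far as these compounds go, with only methoxy and methyl read at the first position, it remains open whether this position can move the number at all, and a primary amine, a carboxylic acid or a longer chain such as n-butyl there would test this more widely. From the compounds shown here alone, the fluoro and methyl comparison is also read only once, with the 4-methylphenyl group in place, so it remains open whether it would read the same with the 4-methoxyphenyl group of compound 2.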